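Halogen swap on the shared core of compound 3

This account rests on a few compounds, and the source may have more. Where it says the series, first, only, none or still open, it means among the compounds named here.

Compound 1 `CCOC(=O)c1cc([Se]c2ccccc2)c2cc(Br)ccc2n1` gives 12400 nM in a functional assay on SK-MEL-147 cells (Homo sapiens) for cytotoxicity, read by MTT assay, with a stated time of 24 h; a higher number here means that more compound is needed for the effect, a lower number that less compound is needed. Within the data shown here, compound 3 `CCOC(=O)c1cc([Se]c2ccccc2)c2cc(C)ccc2n1` gives 12000 nM in this assay, and the step of a 1.0-fold lower number from compound 1 to compound 3 (0.01 log units; within the scatter) is the only measured change at this aromatic carbon. Compound 2 `COc1ccc2nc(-c3c(Cl)cccc3Cl)cc([Se]c3ccccc3)c2c1` reaches only a limit in this assay, > 150000 nM; this is the limit noted as the limit of > 150000 nM in this assay, at which 1 of the 3 values shown sits. Compound 3 thus holds the lowest of the two numbers, with compound 1 nearest and within the scatter. Compound 4 `CCOC(=O)c1cc([Se]c2ccccc2)c2cc(Cl)ccc2n1` differs from compound 3 in one place (chloro in place of methyl on an aromatic carbon). Since bromo and methyl at this carbon gave numbers within the scatter of each other, no step beyond the scatter is expected for chloro in this assay. Compound 4 is therefore estimated at 12000 nM in this assay, from 6000 nM to 25000 nM, an expected step of no change at the digits printed from compound 3 to compound 4 (within the scatter).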

Compound 4, half-maximal effective concentration: 47100 nM
Estimate against measurement, compound 4: 3.9-fold (0.59 log units) below; the measured number lies above the stated range.
By their numbers in this assay, from the lowest: compounds 3 and 1 (each within the scatter of the next); then compound 4. At a limit, above all of these: compound 2.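

Chloro in place of methyl gives a 3.9-fold higher number from compound 3 to compound 4 (0.59 log units; beyond the scatter) in this assay and chloro in place of bromo gives a 3.8-fold higher number from compound 1 to compound 4 (0.58 log units; beyond the scatter) in the same read-out, so this aromatic carbon does not tolerate every small group alike. The two halogens do not group together here: bromo stays within the scatter of methyl, while chloro stands apart from both. Where an amine or a carboxylic acid at this carbon would fall remains open. No measured property shown bears on these steps.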